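Tetrahydrofuran epimer of compound 3 in the lactam series

This account rests on a few compounds, and the source may have more. Where it says the series, first, only, none or still open, it means among the compounds named here.

Measured so far:
compound 1 `COC(c1cc(Cl)c2c(c1Cl)C(=O)N(Cc1c(C)cc(C)[nH]c1=O)CC2)C1CCOC1`: 1100 nM; 494 nM; 47 nM; 7 nM (4 entries)
compound 2 `CCOC(c1cc(Cl)c2c(c1Cl)C(=O)N(Cc1c(C)cc(C)[nH]c1=O)CC2)C1CS(=O)(=O)C1`: 6080 nM; 62 nM (2 entries)
compound 3 `Cc1cc(C)c(CN2CCc3c(Cl)cc([C@@H](CO)[C@@H]4CCCO4)c(Cl)c3C2=O)c(=O)[nH]1`: 1570 nM

In an assay on cells for inhibition of histone-lysine N-methyltransferase EZH2 (Homo sapiens), read by ELISA, with a stated time of 72 h (on this read-out lower numbers stand for stronger inhibition and higher numbers for weaker inhibition), compound 1 gives 1100 nM; 494 nM; 47 nM; 7 nM (4 entries) and compound 2 gives 6080 nM; 62 nM (2 entries). Both spread widely across repeats, as the several entries of compound 1 in this assay, 1100 nM; 494 nM; 47 nM; 7 nM (4 entries) and the several entries of compound 2 in this assay, 6080 nM; 62 nM (2 entries) show, so a single reading in this assay carries limited weight. Compound 3 gives 1570 nM in this assay. For the measured compounds named here, that is its only number. Two further entries for compound 3 give no single number.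

Compound 4 `Cc1cc(C)c(CN2CCc3c(Cl)cc([C@@H](CO)[C@H]4CCCO4)c(Cl)c3C2=O)c(=O)[nH]1` is not yet measured. It differs from compound 3 only in configuration: the two compounds have the same atoms and bonds and differ only in configuration as drawn: 1 of 2 stereo elements differ; a stereocentre at a saturated ring carbon is drawn S in compound 3 and R in compound 4. Going by the values given here, no measured pair shows the effect of inverting this centre, so neither direction nor size of the step can be taken from the data. Compound 4 is expected near 900 nM, within 60 nM to 8000 nM. The expected step of a 1.7-fold lower number from compound 3 to compound 4 (0.24 log units; within the scatter) is thus none beyond the scatter, with wide uncertainty.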

Compound 4, half-maximal inhibitory concentration: 1020 nM
Compound 4: middle estimate off by 1.1-fold (0.05 log units), on the low side; the measured number falls inside the stated range.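

For the compounds shown here, the only pair here that differs in one place gives, in this assay, a 1.5-fold lower number from compound 3 to compound 4 (0.19 log units; within the scatter), so inverting this saturated ring carbon produces no step that stands clear of the scatter. Each side of this pair rests on one number, and repeats of a related compound spread far wider than this step: the several entries of compound 1 in this assay, 1100 nM; 494 nM; 47 nM; 7 nM (4 entries)

As far as these compounds go, the second stereocentre is drawn alike in compound 3 and compound 4, so the effect of inverting it remains open. Also open, from the compounds shown here alone, is how an amine or a carboxylic acid in place of the hydroxyl group would read out.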